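The compounds below may be only part of what the source reports. "The series", "measured", "known", "first", "only" and "open" are said of these compounds alone.

Working notes on the series. The compounds share one core, a fused two-ring system carrying a phenyl group, and all have been tested in a functional assay on KB cells (Homo sapiens) for cytotoxicity; a lower number here means that less compound is needed, a higher number that more compound is needed for the effect.

Compound 1 `Nc1c(-c2ccccc2)oc2ccccc2c1=O` gives in this assay only the limit of > 100 ug/mL. Compound 3 `Nc1c(-c2ccccc2)oc2ccc(Cl)cc2c1=O` carries a chloro in place of hydrogen on an aromatic carbon, and in this assay compound 3 likewise gives only the limit of > 100 ug/mL. The step that the two limits leave unreadable from compound 1 to compound 3 is therefore not readable in size. Compound 2 `Cc1ccc2oc(-c3ccccc3)c(Cl)c(=O)c2c1` carries a chloro where compounds 1 and 3 carry the amino, together with a methyl, and in this assay compound 2 also returns only the limit of > 100 ug/mL. Among the measured compounds shown here, compound 3 thus stands where every value so far stands, at the limit of > 100 ug/mL in this assay, at which 3 of the 3 values shown sit, with no number to set it apart from the others.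

Compound 4 `O=c1c(Cl)c(-c2ccccc2)oc2ccc(Cl)cc12` differs from compound 3 by chloro in place of amino on an aromatic carbon. For the measured compounds named here, no measured step covers this change, and the one measured step, a step that the two limits leave unreadable from compound 1 to compound 3, is itself unreadable, so no direction can be drawn from it. Going by the values given here, with every value so far a limit, the step that the limit leaves unreadable from compound 3 to compound 4 is expected to be none beyond the scatter. Compound 4 is accordingly estimated at about 150 ug/mL, between 50 ug/mL and 450 ug/mL, most likely reported again as a limit rather than a number.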

Compound 4, concentration for half-maximal effect: > 100 ug/mL
Compound 4 was reported as a limit (the forecaster's own chance of this, stated with the estimate: 75%); the middle value is on the limit's open side.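

Compound 4 is again a limit and not a number, so the steps to it from compound 3 and from compound 2 cannot be read in size, and the series stays at one place: the limit of > 100 ug/mL in this assay, at which 4 of the 4 values shown sit. The compounds shown leave open whether any change on the shared core gives a readable value in this assay and, if so, how large the steps are.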